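The source may report more compounds than this note shows. Statements on the series, on what has been measured and on what is new or still open speak of the compounds shown alone.

Working notes on the series.

The shared core of compound 1 `COc1ccc(C2Nc3ccccc3C(=O)N2Cc2ccccc2)cc1COc1ccccc1` is kept throughout. In a functional assay on HEK-EM293 cells for agonist activity at Thyrotropin receptor (Homo sapiens), read by ELISA and cAMP accumulation, with a stated time of 1 h (a lower number here means that less compound is needed, a higher number that more compound is needed for the effect), compound 1 gives 2570 nM. Compound 2 `COc1ccc(C2Nc3ccccc3C(=O)N2Cc2ccccc2)cc1COc1cccc(NC(C)=O)c1` carries an additional acetamido group; in this assay compound 2 gives 4340 nM, and the step of a 1.7-fold higher number from compound 1 to compound 2 (0.23 log units; within the scatter) stays within the scatter. Compound 3 `COc1ccc(C2Nc3ccccc3C(=O)N2Cc2ccccc2)cc1CSc1ccc(NC(C)=O)cc1` exchanges the ether linkage for a thioether bearing a 4-acetamidophenyl group; in this assay compound 3 gives 80 nM. The steps of a 32-fold lower number from compound 1 to compound 3 (1.51 log units; beyond the scatter) and a 54-fold lower number from compound 2 to compound 3 (1.73 log units; beyond the scatter) are both large, so compound 3 stands lowest of the three numbers, with compound 1 nearest and compound 2 furthest.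

Compound 4 `COc1ccc(C2Nc3cccc(O)c3C(=O)N2Cc2ccccc2)cc1CSc1ccc(NC(C)=O)cc1` differs from compound 3 by hydroxy in place of hydrogen on an aromatic carbon. Going by the values given here, none of the measured steps touches that part of the molecule: the steps from compound 1 to compound 2 and to compound 3 concern only the benzyl-side substituents. There is therefore no shown step that bears on this change, and no step beyond the scatter is expected in this assay in either direction. On this basis compound 4 is estimated at 80 nM, with a range from 25 nM to 250 nM. The expected step is no change at the digits printed from compound 3 to compound 4 (within the scatter), within the scatter.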

Compound 4, half-maximal effective concentration: 18 nM
Estimate against measurement, compound 4: 4.4-fold (0.65 log units) above; measured number outside the range, below it.
By their numbers in this assay, from the lowest: compound 4; then compound 3; then compounds 1 and 2 (each within the scatter of the next).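

In this assay, hydroxy in place of hydrogen on an aromatic carbon of the fused system of two rings gives a 4.4-fold lower number from compound 3 to compound 4 (0.65 log units; beyond the scatter), a modest step. Going by these compounds alone, this is the first sign that the shared core itself responds to substitution, since the earlier steps changed only the group on the saturated chain carbon and the aromatic ring it carries. Nothing measured here accounts for the step.

The compounds shown leave open whether an amine or a fluorine on this same aromatic carbon would give a step of similar size or direction. Within the data shown here, it also remains open whether hydroxy at this place gives a comparable step on the phenoxy ether of compound 1, as the change is seen only on the thioether of compound 3.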